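This account rests on a few compounds, and the source may have more. Where it says the series, first, only, none or still open, it means among the compounds named here.

Measured so far in an ADME assay for metabolic stability, read by LC-MS, with a stated time of 3 h, at pH 6.5, tested at 50 uM; on this read-out lower numbers stand for a less stable compound and higher numbers for a more stable compound:

- compound 1 `C[C@@H](O)[C@H]1C(=O)N2C3=C(S[C@@H]4CN[C@@H](C4)C(=O)Nc4cccc(c4)C(=O)OC/C=C\COC3=O)[C@H](C)[C@H]12`: compound 1 gives > 95%, which is a limit of the assay
- compound 2 `C[C@@H](O)[C@H]1C(=O)N2C3=C(S[C@@H]4CN[C@@H](C4)C(=O)Nc4cccc(c4)C(=O)OCCCCOC3=O)[C@H](C)[C@H]12`: compound 2 gives > 95%, likewise a limit of the assay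

Compound 1 stands at the cap of this assay, not at a number; (the limit of > 95% in this assay, at which 2 of the 2 values shown sit). Within the data shown here, no step between compound 1 and compound 2 is given, and their two values show only that each reaches the same limit. Compound 3 `Cc1oc(=O)oc1COC(=O)N1C[C@@H]2C[C@H]1C(=O)Nc1cccc(c1)C(=O)OC/C=C\COC(=O)C1=C(S2)[C@H](C)[C@@H]2[C@@H]([C@@H](C)O)C(=O)N12` is the next compound for this assay. Relative to compound 1 it carries a group of 11 heavy atoms (6 carbon, 5 oxygen; one five-membered aromatic ring with 2 hetero atoms) in place of a hydrogen atom, on an amine nitrogen in a ring. Among the measured compounds shown here, no measured step touches this position, so the size of the change cannot be read from the two known compounds. The step of a number at least 5 percentage points lower from compound 1 to compound 3 (that floor lies within the scatter) is expected to be small, if anything a slight move to a lower value, not clearly beyond the scatter. Compound 3 is thus estimated at 90%, with a range from 72% to 99%.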

Compound 3, percent of the compound remaining: > 95%
Compound 3 was reported as a limit; the forecaster's own chance of this, stated with the estimate: 45%; middle value at least 5 percentage points from the limit.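

In this assay compound 3 gives > 95%, a limit and not a number. No step between compound 1 and compound 3 can be read, since both sit at the same limit: the limit of > 95% in this assay, at which 3 of the 3 values shown sit.

The compounds shown leave open whether the group of 11 heavy atoms on the amine nitrogen in a ring changes this read-out at all.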